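From phenyl to 4-fluorophenyl in compound 3

The source may report more compounds than this note shows. Statements on the series, on what has been measured and on what is new or still open speak of the compounds shown alone.

Measured in a functional assay on MDA-MB-453 cells (Homo sapiens) for cytotoxicity, read by MTT assay, with a stated time of 48 h; on this read-out lower numbers stand for stronger inhibition and higher numbers for weaker inhibition:
- compound 1 `COc1cc(C#N)ccc1OCc1nnc(-c2ccc(F)cc2)o1`: 10500 nM
- compound 2 `COc1cc(C#N)ccc1OCc1nnc(-c2ccc(Cl)cc2)o1`: 33900 nM
- compound 3 `N#Cc1ccc(OCc2nnc(-c3ccccc3)o2)cc1F`: > 50000 nM (a limit)

Compound 3 gives > 50000 nM in this assay and this is a limit of the assay, not a number.

Compound 4 `N#Cc1ccc(OCc2nnc(-c3ccc(F)cc3)o2)cc1F` follows from compound 3 by a single change fluoro in place of hydrogen on an aromatic carbon, which turns phenyl into 4-fluorophenyl.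

Within the data shown here, no measured step shows this change directly. The only one at hand is a 3.2-fold higher number from compound 1 to compound 2 (0.51 log units; beyond the scatter) (chloro in place of fluoro on an aromatic carbon), which is modest but beyond the scatter and leaves the fluoro compound with the lower number. It bears on the question only indirectly. Compound 1 also carries 4-fluorophenyl and gives 10500 nM as a true number, although the rest of its structure differs from that of compound 4.

On that basis, a modest move towards a lower number, meaning stronger inhibition, is expected rather than no change. The expected size is uncertain since the starting point is only a limit. The step expected is an at least 1.7-fold lower number from compound 3 to compound 4 (0.25 log units; that floor lies within the scatter) on this estimate. The estimate for compound 4 is 28000 nM with an expected range from 10000 nM to 70000 nM in this read-out.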

Compound 4, half-maximal inhibitory concentration: 25100 nM
Compound 4: middle estimate off by 1.1-fold (0.05 log units), on the high side; low and high end bracket the measured number.
By their numbers in this assay, from the lowest: compound 1; then compounds 4 and 2 (each within the scatter of the next). At a limit, above all of these: compound 3.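

The change from phenyl to 4-fluorophenyl, with fluoro in place of hydrogen on an aromatic carbon para to a large group, gives an at least 1.9-fold lower number from compound 3 to compound 4 (0.29 log units; that floor lies within the scatter). Among these compounds, the earlier compounds showed only chloro in place of fluoro, so this is the first direct reading of what fluoro does compared with hydrogen at this position. In this assay compound 4 gives 25100 nM, a true number. This single change is therefore enough to bring the shared core off the limit. For compound 3 the value remains a limit and not a number: the limit of > 50000 nM in this assay, at which 1 of the 4 values shown sits.

On these data alone, how far the step from phenyl to 4-fluorophenyl really reaches stays open, since only its floor can be read, and that floor alone does not place it beyond the usual scatter. Whether an amine, a carboxylic acid or trifluoromethyl in that same place would give a lower or a higher number than fluoro, and whether the same change would hold on the core of compound 1, is also left open by the compounds shown.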